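A few compounds are considered here, and "the series" means these few. Any claim that something is new, unique, unknown or untested is made for them only; others in the source may bear on it.

Two compounds share a core that carries an ethoxycarbonyl group on a carbon with a double bond to nitrogen. Compound 1 `CCOC(=O)/C=N/c1cnc(Nc2ccc(N3CCN(C)CC3)cc2)nc1NC1CCCC1` gives 19000 nM in a functional assay on HeLa cells (Homo sapiens) for antiproliferative activity, read by MTT assay (on this read-out higher numbers stand for weaker inhibition and lower numbers for stronger inhibition), and compound 2 `CCOC(=O)/C=N/c1cnc(Nc2ccc(N3CCN(C)CC3)cc2)nc1NC(C)C` gives 11500 nM in this assay. For the measured compounds named here, the only measured step, a 1.7-fold lower number from compound 1 to compound 2 (0.22 log units; within the scatter), concerns a group on a nitrogen, not the carbon with a double bond to nitrogen. On the numbers shown, compound 2 holds the lowest of the two, with compound 1 the nearest, within the scatter. Compound 3 `CC(C)Nc1nc(Nc2ccc(N3CCN(C)CC3)cc2)ncc1/N=C/c1ccc(C(F)(F)F)cc1` differs from compound 2 in one place: 4-(trifluoromethyl)phenyl in place of ethoxycarbonyl on a carbon with a double bond to nitrogen. Going by the values given here, no measured step bears on this change, so there is nothing to point in either direction. The step of a 1.3-fold lower number from compound 2 to compound 3 (0.11 log units; within the scatter) is expected to stay within the scatter in this assay. Compound 3 is therefore estimated at 9000 nM in this assay, with a range from 2000 nM to 35000 nM.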

Compound 3, half-maximal inhibitory concentration: > 100000 nM
Compound 3 gave a limit, no number; the forecaster's own chance of this, stated with the estimate: 10%; middle value at least 11-fold (1.04 log units) away from the limit.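

Compound 3 gives > 100000 nM in this assay and this value is a limit of the assay, not a number. The earlier compounds shown here differed only in a group on a nitrogen, within the scatter, whereas the change on the carbon with a double bond to nitrogen gives an at least 8.6-fold higher number from compound 2 to compound 3 (0.93 log units; beyond the scatter) and so shows that this position can move the read-out beyond the scatter. On these data alone, with 4-(trifluoromethyl)phenyl in place of ethoxycarbonyl the read-out moves toward weaker inhibition, but the full size of the step stays unknown, as it rests on a limit: the limit of > 100000 nM in this assay, at which 1 of the 3 values shown sits.

The compounds shown leave open whether the phenyl ring or the trifluoromethyl group accounts for this step, which an unsubstituted phenyl or an amide on that carbon would help to separate. They also leave open whether cyclopentyl on the nitrogen would read the same with 4-(trifluoromethyl)phenyl present.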